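Trimming an Ethyl to a Methyl on Two Cores

The source may hold more compounds than are shown below. What is called first, only, known or untested is meant among the compounds shown, and "the series" means these compounds.

Compound 1 `CC(C(=O)N1CCN(c2ccccc2F)CC1)N1C(=O)CCC1=O` and compound 2 `CCC(C(=O)N1CCN(c2ccccc2F)CC1)N1C(=O)CCC1=O` share one core and differ in a single place. In a functional assay on the whole organism (strain Swiss) with Mus musculus as the target, in the maximal electroshock model, with a stated time of 0.25 h, at a dose of 100 mg/kg by the intraperitoneal route (a lower number here means a weaker effect, a higher number a stronger effect of the compound at the dose given), compound 1 gives 75%, whereas compound 2 gives 0%. The change between them is hydrogen in place of methyl on a saturated chain carbon, two bonds along the chain from an amide-type nitrogen in a ring and a carbonyl carbon, and it made a step of a number 75 percentage points higher from compound 2 to compound 1 (beyond the scatter).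

Compound 3 `CCC(C(=O)N1CCN(c2cccc(C(F)(F)F)c2)CC1)N1C(=O)CCC1=O` is built on a different core; the difference between the two cores is not broken down here. In this assay compound 3 gives 75%, level with compound 1 at the digits given, and far apart from compound 2.

Compound 4 `CC(C(=O)N1CCN(c2cccc(C(F)(F)F)c2)CC1)N1C(=O)CCC1=O` has not yet been measured. It stands to compound 3 exactly as compound 1 stands to compound 2: the change is hydrogen in place of methyl on a saturated chain carbon, two bonds along the chain from an amide-type nitrogen in a ring and a carbonyl carbon, the same change, with the same surroundings on both cores.

The earlier step was large, but compound 3 already shares the highest number of the three, so the read-out has little room to rise. The expected step is a number 10 percentage points higher from compound 3 to compound 4 (within the scatter), resting on compound 3 at 75% and on the earlier rise of a number 75 percentage points higher from compound 2 to compound 1 (beyond the scatter). Compound 4 is therefore expected to give about 85%, most likely between 60% and 100%.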

Compound 4, a percentage reported as activity, at one dose (the size of the read-out at that dose, not a potency): 50%
The estimate for compound 4 lay 35 percentage points above the measured number; the measured number lies below the stated range.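

In this assay, cutting ethyl to methyl gave a number 25 percentage points lower from compound 3 to compound 4 (beyond the scatter), so the change that raised the read-out on the core of compound 1 lowered it on the core of compound 3. The effect of this change therefore did not carry over from one core to the other, either in direction or in size: the same change on two cores in this assay, a number 75 percentage points higher (beyond the scatter) from compound 2 to compound 1 and a number 25 percentage points lower (beyond the scatter) from compound 3 to compound 4, 100 percentage points apart, beyond the scatter of two such steps. For the compounds shown here, this shows that a result for this change on one core cannot simply be assumed on the other, but with only one pair on each core, it neither explains the reversal nor gives a rule for any further core.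

The compounds shown leave open how the read-out would respond on either core to a longer chain, such as propyl, or to a hydroxyl group on that same chain carbon. Also open, on these data alone, is which feature of the cores decides the direction of the step, and whether the reversal would persist at another dose or time.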